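From chloro to methyl: the expected read-out for compound 4

The compounds below may be only part of what the source reports. "The series", "measured", "known", "first", "only" and "open" are said of these compounds alone.

Measured in an ADME assay on SH-SY5Y cells (Homo sapiens) for cytotoxicity, read by MTT assay, with a stated time of 72 h; on this read-out higher numbers stand for weaker inhibition and lower numbers for stronger inhibition:
compound 1 `Cc1ccc(C(=O)N2CCN(CC(=O)N3CCN(CCCc4c[nH]c5ccc(F)cc45)CC3)CC2)cc1`: 119000 nM
compound 2 `COc1ccc2[nH]cc(CCCN3CCN(C(=O)CN4CCN(C(=O)c5ccccc5)CC4)CC3)c2c1`: > 200000 nM, a limit of the assay
compound 3 `COc1ccc2[nH]cc(CCCN3CCN(C(=O)CN4CCN(C(=O)c5ccc(Cl)cc5)CC4)CC3)c2c1`: 159000 nM

Among the compounds with values here, compound 3 lies within the scatter of compound 1, the only other compound with a number, since compound 2 gives only a limit. Compound 4 `COc1ccc2[nH]cc(CCCN3CCN(C(=O)CN4CCN(C(=O)c5ccc(C)cc5)CC4)CC3)c2c1` departs from compound 3 by methyl in place of chloro on an aromatic carbon. Within the data shown here, one measured step bears on this place: an at least 1.2-fold lower number from compound 2 to compound 3 (0.09 log units; that floor lies within the scatter), for chloro in place of hydrogen on an aromatic carbon. Compound 1, which also carries 4-methylphenyl, gives 119000 nM in this assay. No shift beyond the scatter is therefore expected, in either direction. The expected step is a 1.1-fold lower number from compound 3 to compound 4 (0.03 log units; within the scatter). Compound 4 is estimated at 150000 nM, with an expected range of 85000 nM to 260000 nM.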

Compound 4, half-maximal inhibitory concentration: > 200000 nM
Compound 4: no number, only a limit; the forecaster's own chance of this, stated with the estimate: 20%; at least 1.3-fold (0.12 log units) between middle value and limit.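

In this assay compound 4 gives > 200000 nM, which is a limit of the assay. Methyl in place of chloro on the aromatic carbon gives an at least 1.2-fold higher number from compound 3 to compound 4 (0.09 log units; that floor lies within the scatter), and methoxy in place of fluoro gives an at least 1.6-fold higher number from compound 1 to compound 4 (0.22 log units; that floor lies within the scatter), so neither change is shown to move the read-out beyond the scatter. The step linking compound 2 with compound 4 cannot be read, and this position stays only loosely defined: the limit of > 200000 nM in this assay, at which 2 of the 4 values shown sit.

The compounds shown leave open whether an amine or a carboxylic acid in place of methyl on this ring would give a number rather than a limit.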